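Trading an open ester chain for a ring-bound amide

The source may hold more compounds than are shown below. What is called first, only, known or untested is meant among the compounds shown, and "the series" means these compounds.

Measured compounds:
compound 1 `CCOC(=O)CNC(=O)NCc1ccc(C(=O)N2CCCCc3ccccc32)cc1C` gives 140 nM
compound 2 `Cc1cc(C(=O)N2CCCCc3ccccc32)ccc1CNC(=O)NCC(=O)OC(C)C` gives 140 nM
compound 3 `Cc1cc(C(=O)N2CCCCc3ccccc32)ccc1CNC(=O)N1CCC[C@H]1C(=O)OC(C)(C)C` gives 390 nM

All three share one core and differ only in the group attached to a carbonyl carbon. In a functional assay on HEK293 cells for agonist activity at Vasopressin V2 receptor (Homo sapiens), read by a luciferase reporter and cAMP accumulation (on this read-out higher numbers stand for an effect only at larger amounts of compound and lower numbers for an effect already at smaller amounts), compound 2 sits level with compound 1, the two together giving the lowest numbers of the three; the step of no change at the digits printed from compound 1 to compound 2 (within the scatter) lies within the scatter, and the step of a 2.8-fold higher number from compound 2 to compound 3 (0.44 log units; beyond the scatter) lies beyond it.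

Compound 4 `Cc1cc(C(=O)N2CCCCc3ccccc32)ccc1CNC(=O)N1CCC[C@@H]1C(=O)N(C)C` is not yet measured. Against compound 2 the change is 2-(dimethylcarbamoyl)pyrrolidin-1-yl in place of ((isopropoxycarbonyl)methyl)amino on a carbonyl carbon. The pyrrolidine ring with its single stereocentre already appears in compound 3, which carries a tert-butyl ester on it rather than a dimethylamide; the step of a 2.8-fold higher number from compound 2 to compound 3 (0.44 log units; beyond the scatter) is therefore the closest guide, with a 2.8-fold higher number from compound 1 to compound 3 (0.44 log units; beyond the scatter) telling the same story. As far as these compounds go, whether the dimethylamide behaves like the ester is unknown from these compounds, so a modest rise of similar size is the expectation, the step of a 2.5-fold higher number from compound 2 to compound 4 (0.40 log units; beyond the scatter) being estimated in the same direction. Compound 4 is estimated at 350 nM, within a range of 120 nM to 1000 nM.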

Compound 4, half-maximal effective concentration: 380 nM
For compound 4 the middle estimate is 1.1-fold (0.04 log units) below the measured one, within the range that was stated.
By their numbers in this assay, from the lowest: compounds 1 and 2 (each within the scatter of the next); then compounds 4 and 3 (each within the scatter of the next).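

Compound 4 shows that the rise tied to the pyrrolidine ring on this carbonyl carbon does not depend on a tert-butyl ester: in this assay the dimethylamide gives a 2.7-fold higher number from compound 2 to compound 4 (0.43 log units; beyond the scatter) and likewise a 2.7-fold higher number from compound 1 to compound 4 (0.43 log units; beyond the scatter). The ester-to-dimethylamide exchange on the ring leaves only a 1.0-fold lower number from compound 3 to compound 4 (0.01 log units; within the scatter), even though compound 3 and compound 4 are drawn with opposite handedness at their stereocentre, so this step carries both differences at once and neither shows up alone. Across these four compounds, the two open-chain esters share the lowest numbers and the two pyrrolidines the higher ones, with no compound going against this, but nothing measured here explains the pattern [ ].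

The compounds shown cannot tell whether the ring itself goes with the rise or the change from 1 hydrogen-bond donor to 0 in the entering group, as the two come together. Also open, as far as these compounds go, are how the mirror-image form of compound 4 would read, and whether a carboxylic acid or a primary amide on the pyrrolidine ring would fall level with compound 4 or elsewhere.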